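Swapping the ether substituent on a cyanophenyl tetrazole

This account rests on a few compounds, and the source may have more. Where it says the series, first, only, none or still open, it means among the compounds named here.

Compound 1 `N#Cc1cc(-n2nnc(-c3ccccn3)n2)cc([N+](=O)[O-])c1`: 42 nM
Compound 2 `COc1cc(C#N)cc(-n2nnc(-c3ccccn3)n2)c1`: 6 nM
Compound 3 `N#Cc1cc(OCC2CC2)cc(-n2nnc(-c3ccccn3)n2)c1`: 271 nM

Three compounds share one core and differ only in the group on one aromatic carbon. In an assay on cell membranes for binding affinity to metabotropic glutamate receptor 5 (Rattus norvegicus) (on this read-out lower numbers stand for stronger inhibition and higher numbers for weaker inhibition), compound 2 gives the lowest number, compound 1 sits in the middle, and compound 3 gives the highest of the three. The steps to compound 3 are a 6.5-fold higher number from compound 1 to compound 3 (0.81 log units; beyond the scatter) and a 45-fold higher number from compound 2 to compound 3 (1.65 log units; beyond the scatter), so compound 3 stands clearly weakest here.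

Compound 4 `N#Cc1cc(Oc2cccnc2)cc(-n2nnc(-c3ccccn3)n2)c1` keeps the oxygen on the ring but changes what hangs from it: pyridin-3-yl in place of cyclopropylmethyl on an oxygen on an aromatic ring. For the measured compounds named here, no measured step tests an aromatic group at this oxygen. What the measured steps show is that the small methoxy of compound 2 does best, and that adding the cyclopropyl of compound 3 costs much, as the step from compound 2 to compound 3 shows. A pyridinyl group is also larger than methyl, so compound 4 is expected to stay near compound 3 rather than return toward compound 2, with a step of about a 1.8-fold lower number from compound 3 to compound 4 (0.26 log units; within the scatter) that may not exceed the scatter. Compound 4 is therefore estimated at 150 nM in this assay, likely between 30 nM and 800 nM.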

Compound 4, inhibition constant: 16 nM
Compound 4: middle estimate off by 9.4-fold (0.97 log units), on the high side; the whole stated range lies above it.
By their numbers in this assay, from the lowest: compound 2; then compound 4; then compound 1; then compound 3.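

In this assay, the number of heavy atoms alone does not set the result at this oxygen: pyridin-3-yl has more of them than cyclopropylmethyl, yet replacing one with the other gives a 17-fold lower number from compound 3 to compound 4 (1.23 log units; beyond the scatter). Methoxy still holds the lowest number, with a 2.7-fold higher number from compound 2 to compound 4 (0.43 log units; beyond the scatter), while (pyridin-3-yl)oxy improves on nitro, with a 2.6-fold lower number from compound 1 to compound 4 (0.42 log units; beyond the scatter), so a large group on this oxygen can still give a low number. Nothing available here explains why pyridin-3-yl does so much better than cyclopropylmethyl.

From the compounds shown here alone, whether the ring nitrogen of pyridin-3-yl matters stays open: a phenyl group on this oxygen would test its presence, and pyridin-4-yl its place in the ring. An ethyl group would show how quickly the number rises as the chain grows beyond methyl.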